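Chlorine position on the aryl group of compound 2

This account rests on a few compounds, and the source may have more. Where it says the series, first, only, none or still open, it means among the compounds named here.

Two compounds of the shared core have numbers in a functional assay on HepG2 cells (Homo sapiens) for antiproliferative activity, read by MTT assay, with a stated time of 24 h; on this read-out lower numbers stand for stronger inhibition and higher numbers for weaker inhibition. Compound 1 `O=c1[nH]cc(S(=O)(=O)Nc2ccc(-c3cn(-c4ccccc4)nn3)cc2)c(=O)[nH]1` gives 18000 nM in this assay. Compound 2 `O=c1[nH]cc(S(=O)(=O)Nc2ccc(-c3cn(-c4cccc(Cl)c4)nn3)cc2)c(=O)[nH]1` gives 2020 nM in this assay. For the measured compounds named here, the single measured step, an 8.9-fold lower number from compound 1 to compound 2 (0.95 log units; beyond the scatter), shows that chloro in place of hydrogen on the aromatic carbon lowers the number well beyond the scatter. Compound 2 therefore holds the lowest of the two numbers shown, with compound 1 the nearest and beyond the scatter above it.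

Compound 3 `O=c1[nH]cc(S(=O)(=O)Nc2ccc(-c3cn(-c4ccc(Cl)cc4)nn3)cc2)c(=O)[nH]1` is not yet measured in this assay. Its change from compound 2 is 4-chlorophenyl in place of 3-chlorophenyl on an aromatic nitrogen. Going by the values given here, no measured step moves the chlorine from one place to another on that ring; the only step, an 8.9-fold lower number from compound 1 to compound 2 (0.95 log units; beyond the scatter), concerns the presence of the chlorine rather than where it sits, so it bears on compound 3 only in that the chlorine is kept and a return toward the number of compound 1 is not expected. The expected step from compound 2 to compound 3 is therefore a 1.2-fold higher number from compound 2 to compound 3 (0.09 log units; within the scatter), within the scatter. For compound 3 the estimated value in this assay is 2500 nM, with a range from 900 nM to 7000 nM.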

Compound 3, half-maximal inhibitory concentration: 1980 nM
Compound 3: the middle estimate sits 1.3-fold (0.10 log units) above what was measured; low and high end bracket the measured number.
By their numbers in this assay, from the lowest: compounds 3 and 2 (each within the scatter of the next); then compound 1.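

In this assay, 4-chlorophenyl in place of 3-chlorophenyl on the aromatic nitrogen gives a 1.0-fold lower number from compound 2 to compound 3 (0.01 log units; within the scatter), so the two chlorine placements cannot be told apart on this read-out. The step from the unsubstituted phenyl now holds for a second placement of the chlorine: a 9.1-fold lower number from compound 1 to compound 3 (0.96 log units; beyond the scatter), close in size to an 8.9-fold lower number from compound 1 to compound 2 (0.95 log units; beyond the scatter), so for these two chlorophenyl groups the presence of the chlorine shows in the number and its place on the ring does not. Nothing in the available data explains why the two placements read alike.

From the compounds shown here alone, it remains open whether the step belongs to chlorine in particular or whether another group on this aryl ring, such as fluoro, methoxy, trifluoromethyl or an amine, would give a number in the range of compound 2 and compound 3. Going by these compounds, it is also open whether a second chlorine on the same ring would take the number beyond the scatter of these two compounds, or whether the effect of a single chlorine is the whole of what this ring offers.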